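The compounds below may be only part of what the source reports. "The series", "measured", "known", "first", "only" and "open" are said of these compounds alone.

In an ADME assay on HEK293 cells (Homo sapiens) for cytotoxicity, with a stated time of 72 h (a higher number here means that more compound is needed for the effect, a lower number that less compound is needed), compound 1 (`O=C(O)COc1cc(Cl)c(C(=O)Nc2cccc(-c3nc4ccccc4s3)c2)cc1[N+](=O)[O-]`) gives > 25000 nM as a limit of the assay, not a number. Compound 2 (`O=C(Nc1ccc(O)c(-c2nc3ccccc3s2)c1)c1cc([N+](=O)[O-])ccc1Cl`) gives > 25000 nM as a limit too. Compound 3 (`O=C(Nc1ccc(Cl)c(-c2nc3ccccc3s2)c1)c1cc([N+](=O)[O-])ccc1Cl`) likewise gives > 25000 nM as a limit. Among the measured compounds shown here, the one measured step (a step that the two limits leave unreadable from compound 2 to compound 3) is chloro in place of hydroxy on an aromatic carbon, a different change from the one followed here. Compound 4 (`COc1cc(Cl)c(C(=O)Nc2cccc(-c3nc4ccccc4s3)c2)cc1[N+](=O)[O-]`) turns carboxymethoxy into methoxy (hydrogen in place of carboxy on a saturated chain carbon bound to an oxygen on an aromatic ring). For compound 1 no measured size carries over because the limit of > 25000 nM in this assay, at which 3 of the 3 values shown sit, and so no step beyond the scatter is expected, in either direction. The expected change is a number no higher from compound 1 to compound 4 (the limit leaves the size open) in this assay on this estimate. For compound 4 the estimated value is 25000 nM (expected range 12000 nM to 50000 nM).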

Compound 4, half-maximal effective concentration: > 25000 nM
Compound 4: only a limit was reported; the forecaster's own chance of this, stated with the estimate: 80%; the middle value lies on the limit itself.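

Compound 1 and compound 4 both sit at a limit of this assay, not at a number, so no step can be read between them. The compounds shown leave open at what concentration any of them would produce the effect: the limit of > 25000 nM in this assay, at which 4 of the 4 values shown sit.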